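A few compounds are considered here, and "the series" means these few. Any claim that something is new, unique, unknown or untested is made for them only; others in the source may bear on it.

In a functional assay on SF-295 cells (Homo sapiens) for cytotoxicity, read by sulforhodamine B assay, with a stated time of 48 h (a lower number here means a stronger inhibitor of growth, a higher number a weaker inhibitor of growth), compound 1 (`COc1ccc(C(=O)c2cc(OC)c(OC)c(OC)c2)c(OC)c1O`) gives 19.9 nM. Where compound 1 carries a hydroxy group, compound 2 (`COc1ccc(C(=O)c2cc(OC)c(OC)c(OC)c2)c(OC)c1N`) carries an amino group and gives 19.9 nM, which places it level with compound 1. Compound 3 (`COc1ccc(C(=O)c2cc(OC)c(OC)c(OC)c2)c(OC)c1NC(C)=O`) differs from compound 2 by one change, acetyl in place of hydrogen on a nitrogen on an aromatic ring. This turns amino to acetamido.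

Going by the values given here, only one measured step offers any guide: no change at the digits printed from compound 1 to compound 2 (within the scatter). Among the compounds with values here, that step exchanges hydroxy for amino, so it says little about adding an acetyl, and no measured compound carries one. With so little evidence, the expected result in this assay is a moderate move toward weaker growth inhibition, a 7.5-fold higher number from compound 2 to compound 3 (0.88 log units; beyond the scatter), and this expectation is uncertain. Compound 3 is estimated at 150 nM, with an expected range of 30 nM to 1000 nM.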

Compound 3, concentration for 50% growth inhibition: 293 nM
Estimate against measurement, compound 3: 2.0-fold (0.29 log units) below, and the stated range covers the measured number.
By their numbers in this assay, from the lowest: compounds 1 and 2 (each within the scatter of the next); then compound 3.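

Until now this position looked tolerant, since hydroxy and amino read alike, but the tolerance has a limit. In this assay, acetyl on the nitrogen on an aromatic ring brings a large loss (a 15-fold higher number from compound 2 to compound 3 (1.17 log units; beyond the scatter)), and the exchange of hydroxy for acetamido gives a step of the same size (a 15-fold higher number from compound 1 to compound 3 (1.17 log units; beyond the scatter)), so acetamido cannot stand in for either smaller group here. Nothing available explains why growth inhibition weakens with this change.

As far as these compounds go, it remains open whether the loss belongs to the acetyl group itself or to any substituent on this nitrogen. A single methyl group on the nitrogen, a smaller formyl group or a methanesulfonyl group would help separate these possibilities.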